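Heteroaryl exchange on the thioether in a weak series

The compounds below may be only part of what the source reports. "The series", "measured", "known", "first", "only" and "open" are said of these compounds alone.

Compound 1 `Cc1nnc(SCC(=O)[C@H](CC(=O)O)NC(=O)[C@@H](NC(=O)COc2cccc3ccccc23)C(C)C)s1` gives 190000 nM in a functional assay on Jurkat cells (Homo sapiens) for inhibition; a lower number here means a stronger inhibitor, a higher number a weaker inhibitor. Compound 2 `CC(C)[C@H](NC(=O)COc1cccc2ccccc12)C(=O)N[C@@H](CC(=O)O)C(=O)CSc1nc2ccccc2o1` returns only the assay limit, > 200000 nM, in this assay. Compound 3 `CC(C)[C@H](NC(=O)COc1cccc2ccccc12)C(=O)N[C@@H](CC(=O)O)C(=O)CSc1nc2ccccc2s1` likewise returns only the limit > 200000 nM in this assay, so compound 3 stands at the ceiling of the numbers shown, without a number of its own. Compound 4 `CC(C)[C@H](NC(=O)COc1cccc2ccccc12)C(=O)N[C@@H](CC(=O)O)C(=O)CSc1nccc(C(F)(F)F)n1` differs from compound 3 by 4-(trifluoromethyl)pyrimidin-2-yl in place of 1,3-benzothiazol-2-yl on a sulfur. The steps bearing on this kind of exchange are an at least 1.0-fold higher number from compound 1 to compound 2 (0.02 log units; that floor lies within the scatter) and an at least 1.0-fold higher number from compound 1 to compound 3 (0.02 log units; that floor lies within the scatter); the step that the two limits leave unreadable from compound 2 to compound 3 cannot be read, as both sit at the limit of > 200000 nM in this assay, at which 2 of the 3 values shown sit. Neither exchange moved the number beyond the scatter, so no step beyond the scatter is expected here. Compound 4 is therefore expected to give 200000 nM, between 100000 nM and 400000 nM, in this assay. The expected step is a number no higher from compound 3 to compound 4 (the limit leaves the size open), with a limit rather than a number the likelier outcome.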

Compound 4, half-maximal inhibitory concentration: > 200000 nM
Compound 4 ended at the assay's limit (the forecaster's own chance of this, stated with the estimate: 60%); the middle value lies on the limit itself.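

A single six-membered aromatic ring, 4-(trifluoromethyl)pyrimidin-2-yl, on this sulfur also gives only a limit in this assay, so the outcome is not confined to the two-ring groups of compound 2 and compound 3. Against 5-methyl-1,3,4-thiadiazol-2-yl the change is an at least 1.0-fold higher number from compound 1 to compound 4 (0.02 log units; that floor lies within the scatter). The steps linking compound 4 with compound 2 and compound 3 cannot be read, and the series remains crowded at the ceiling: the limit of > 200000 nM in this assay, at which 3 of the 4 values shown sit.

On these data alone, whether any group on this sulfur can give a reading clearly under the limit remains open. A phenyl or an amine-bearing heteroaryl there would test this.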